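Imidazoline in Place of Isopropylamidine: Expected Cytotoxicity

The compounds below may be only part of what the source reports. "The series", "measured", "known", "first", "only" and "open" are said of these compounds alone.

Measured compounds:
compound 1 `N=C(N)c1ccc2cc(-c3cccc(OCCCCCCOc4ccccc4)c3)oc2c1` 4300 nM
compound 2 `N=C(N)c1ccc2cc(-c3ccc(OCCCOc4ccccc4)cc3)oc2c1` 8600 nM
compound 3 `CC(C)NC(=N)c1ccc2cc(-c3ccc(OCCCOc4ccccc4)cc3)oc2c1` 49900 nM

In an ADME assay on L6 cells (Rattus norvegicus) for cytotoxicity, read by resazurin assay, with a stated time of 70 h (a higher number here means a weaker inhibitor, a lower number a stronger inhibitor), compound 3 gives 49900 nM, the highest of the three numbers. Its nearest neighbour is compound 2, which gives 8600 nM, and the most distant is compound 1 with 4300 nM.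

Compound 4 `c1ccc(OCCCOc2ccc(-c3cc4ccc(C5=NCCN5)cc4o3)cc2)cc1` differs from compound 3 in one place: a group of 5 heavy atoms (3 carbon, 2 nitrogen; one five-membered non-aromatic ring with 2 hetero atoms) in place of a group of 6 heavy atoms (4 carbon, 2 nitrogen; no ring), on an aromatic carbon. The cyclic group that enters is closed back onto itself; the open group that leaves carries the isopropyl on one of its nitrogens.

Going by the values given here, only one measured step bears on this change, and it bears on it only in part: a 5.8-fold higher number from compound 2 to compound 3 (0.76 log units; beyond the scatter). That step shows that building out the amine nitrogen of the amidine moved the number upward by a modest amount. Compound 4 neither keeps the isopropyl nor returns to the bare amidine of compound 2; its ring joins the two nitrogens instead. Among the compounds with values here, no step in the set shows this particular exchange, so the direction is uncertain. The estimate therefore puts compound 4 between the two, with a step of a 2.5-fold lower number from compound 3 to compound 4 (0.40 log units; beyond the scatter) expected downward, within a wide range.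

Compound 4 is thus expected at 20000 nM, with a range from 6000 nM to 70000 nM.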

Compound 4, half-maximal inhibitory concentration: 16800 nM
The estimate for compound 4 lay 1.2-fold (0.08 log units) above the measured number, and the stated range covers the measured number.
By their numbers in this assay, from the lowest: compounds 1, 2 and 4 (each within the scatter of the next, the first and the last beyond it); then compound 3.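

In this assay, joining the two nitrogens into the five-membered non-aromatic ring gives a 3.0-fold lower number from compound 3 to compound 4 (0.47 log units; beyond the scatter), so the high number of compound 3 does not carry over to this cyclic group on the same aromatic carbon. Set against the bare amidine, the ring gives a 2.0-fold higher number from compound 2 to compound 4 (0.29 log units; within the scatter), which leaves compound 4 and compound 2 indistinguishable in this assay even though the two groups differ in heavy atoms and in ring content. Among the three groups seen at this position on the shared core, only the open group carrying the isopropyl stands apart from the other two by more than the scatter, and nothing at hand gives a reason for this.

Going by these compounds, it remains open whether a smaller or larger substituent on the amine nitrogen, such as an ethyl or a tert-butyl group, would raise the number as the isopropyl does, or whether a six-membered ring closed across the two nitrogens would behave like the five-membered one. On these data alone, it is equally open whether the same exchange would read the same way on the core of compound 1, with its hexyl-length chain.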